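Working notes: tolerated concentrations across four related compounds

The source may report more compounds than this note shows. Statements on the series, on what has been measured and on what is new or still open speak of the compounds shown alone.

Measured so far in an ADME assay on C8166 cells (Homo sapiens) for cytotoxicity, read by colorimetric assay and MTT assay; a lower number here means that less compound is tolerated, a higher number that more compound is tolerated:
compound 1 `Cc1cc(S(N)(=O)=O)ccc1NC(=O)COc1ccc2cc(Br)ccc2c1C(=O)c1cccc(Cl)c1` gives 6800 nM.
compound 2 `Cc1ccc(C(=O)c2c(OCC(=O)Nc3ccc(S(N)(=O)=O)cc3C)ccc3cc(Br)ccc23)cc1C` gives 85200 nM.
compound 3 `Cc1cc(S(N)(=O)=O)ccc1NC(=O)COc1ccc2cc(C#N)ccc2c1C(=O)c1cccc(Cl)c1` is reported only as a limit, > 374000 nM.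

Two single changes connect these three. From compound 1 to compound 2 the change is 3,4-dimethylphenyl in place of 3-chlorophenyl on a carbonyl carbon, and the step in this assay is a 13-fold higher number from compound 1 to compound 2 (1.10 log units; beyond the scatter). From compound 1 to compound 3 the cores differ by cyano in place of bromo on an aromatic carbon, and the step is an at least 55-fold higher number from compound 1 to compound 3 (1.74 log units; beyond the scatter). The second step is bounded only from one side, since compound 3 sits at the limit of the assay, (the limit of > 374000 nM in this assay, at which 1 of the 3 values shown sits).

Compound 4 `Cc1ccc(C(=O)c2c(OCC(=O)Nc3ccc(S(N)(=O)=O)cc3C)ccc3cc(C#N)ccc23)cc1C` is not yet measured. It differs from compound 3 by 3,4-dimethylphenyl in place of 3-chlorophenyl on a carbonyl carbon. This is the same change as from compound 1 to compound 2, made on the core of compound 3 instead of the core of compound 1; the place of the change reads the same in both pairs.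

Compound 3 already lies at the limit, so whatever the change adds cannot be read as a number from compound 3 alone. The expectation for compound 4 rests on compound 1 to compound 2, where the change gave a 13-fold higher number from compound 1 to compound 2 (1.10 log units; beyond the scatter), and on compound 3 standing at > 374000 nM. Compound 4 is therefore expected to be at or beyond the limit as well, with an estimated step that the limit leaves unreadable from compound 3 to compound 4. The estimate for compound 4 is 1500000 nM, between 374000 nM and 6000000 nM, and most likely the assay will again report only a limit.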

Compound 4, half-maximal cytotoxic concentration: > 379000 nM
Compound 4 ended at the assay's limit; the forecaster's own chance of this, stated with the estimate: 90%; the middle value lies beyond the limit too.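

In this assay, cyano in place of bromo gives an at least 4.4-fold higher number from compound 2 to compound 4 (0.64 log units; beyond the scatter), so the direction seen on the core carrying 3-chlorophenyl also holds on the core carrying 3,4-dimethylphenyl. Only the direction carries over, and both steps are open-ended, so the compounds do not show whether the size of the change is the same on the two cores: the same change on two cores in this assay, an at least 55-fold higher number (1.74 log units; beyond the scatter) from compound 1 to compound 3 and an at least 4.4-fold higher number (0.64 log units; beyond the scatter) from compound 2 to compound 4; the limit leaves it open whether they differ

The step from compound 3 to compound 4 cannot be read with both compounds at limits, so the rise seen for 3,4-dimethylphenyl in place of 3-chlorophenyl on the bromo core is neither confirmed nor contradicted on the cyano core.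

Going by these compounds, it remains open how far beyond the limits compound 3 and compound 4 lie, and therefore whether the aryl group on the carbonyl carbon still matters once cyano is present. Also open, on these data alone, is whether an amine or a carboxylic acid in place of the cyano would keep the number at the limit, and whether a longer chain in place of the methyl groups of the 3,4-dimethylphenyl would shift it on either core.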